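From bromo to cyclopropylmethoxy: an unmeasured analogue

The source may hold more compounds than are shown below. What is called first, only, known or untested is meant among the compounds shown, and "the series" means these compounds.

Compound 1, `COc1cc(/C=C/c2cc(=O)c3c(OC)cc(OC)cc3o2)cc(OC)c1`: 23700 nM
Compound 2, `COc1cc(OC)c2c(=O)cc(/C=C/c3ccc(Br)cc3)oc2c1`: > 40000 nM

In a functional assay on SKHep cells (Homo sapiens) for antiproliferative activity, read by MTT assay, with a stated time of 12 h (on this read-out lower numbers stand for stronger inhibition and higher numbers for weaker inhibition), compound 1 gives 23700 nM. Compound 2 gives no number but only a limit in this assay, > 40000 nM, and so sits at the limit of > 40000 nM in this assay, at which 1 of the 2 values shown sits. Compound 3, `COc1cc(OC)c2c(=O)cc(/C=C/c3ccc(OCC4CC4)cc3)oc2c1`, has not yet been measured. It differs from compound 2 by cyclopropylmethoxy in place of bromo on an aromatic carbon. Within the data shown here, no measured step shows how this change acts, and the step of an at least 1.3-fold lower number from compound 2 to compound 3 (0.12 log units; that floor lies within the scatter) is expected to be small, not beyond the scatter, in this assay. Compound 3 is therefore expected to give about 30000 nM, in a range from 8000 nM to 100000 nM.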

Compound 3, half-maximal inhibitory concentration: 22100 nM
For compound 3 the middle estimate is 1.4-fold (0.13 log units) above the measured one; measured number inside the range.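

On this aromatic carbon, cyclopropylmethoxy brings a readable number into this assay, where bromo gave none: compound 3 gives 22100 nM. From the compounds shown here alone, the change gives an at least 1.8-fold lower number from compound 2 to compound 3 (0.25 log units; that floor lies within the scatter), so it is a floor, and the full size of the step remains unknown. Compound 2 carries only a limit and no number: the limit of > 40000 nM in this assay, at which 1 of the 3 values shown sits.

The compounds shown leave open what an amine or a carboxylic acid on this aromatic carbon would give. They also do not separate the three-membered ring from its oxygen, as a simple methoxy group here would.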